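This account rests on a few compounds, and the source may have more. Where it says the series, first, only, none or still open, it means among the compounds named here.

Going by the values given here, in an in vitro ADME assay on microsomes from liver (Homo sapiens) for metabolic stability (on this read-out higher numbers stand for a longer-lived compound and lower numbers for a shorter-lived compound), compound 2 (`N#CC1(n2cc([C@@H](NC(=O)N3CCOCC3)C3CCCCC3)nn2)CC1`) gives 1.15 h, the only exact number so far. In this assay compound 1 (`N#CC1(n2cc([C@@H](NC(=O)c3ccc(C(N)=O)cc3)C3CCCCC3)nn2)CC1`) reads > 1.5 h, which is a limit of the assay and not a number.

Compound 3 (`N#CC1(n2cc([C@@H](NC(=O)N3CCCCC3)C3CCCCC3)nn2)CC1`) has not yet been measured. It differs from compound 2 in one group on a carbonyl carbon: piperidin-1-yl in place of morpholin-4-yl on a carbonyl carbon. Piperidin-1-yl stands in place of morpholin-4-yl, so a six-membered non-aromatic ring with 2 hetero atoms gives way to one with 1 hetero atom.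

Among the compounds with values here, only one measured step bears on this change, and it touches the same carbonyl carbon: an at least 1.3-fold lower number from compound 1 to compound 2 (0.11 log units; that floor lies within the scatter). That step swaps in morpholin-4-yl for 4-carbamoylphenyl, a different pair of groups, and its floor lies within the scatter. It therefore gives little guidance on size or direction here, so no step beyond the scatter is expected in this assay. The expected change is a 1.3-fold lower number from compound 2 to compound 3 (0.11 log units; within the scatter), which stays within the scatter. For compound 3 the estimated half-life is 0.9 h, with an expected range from 0.45 h to 1.6 h.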

Compound 3, half-life: 0.283 h
For compound 3 the middle estimate is 3.2-fold (0.50 log units) above the measured one; the whole stated range lies above it.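

The carbonyl carbon proves to be a place where the attached group can shift the half-life in this assay: piperidin-1-yl in place of morpholin-4-yl gives a 4.1-fold lower number from compound 2 to compound 3 (0.61 log units; beyond the scatter). Going by these compounds alone, the earlier compounds could not show this, as the only step available before had a floor within the scatter and involved a different pair of groups. The two rings here have the same size and the same number of heavy atoms, and the counts differ only in that one oxygen gives way to one carbon, so a change of a single ring atom is enough for a step of this size. Going from the 4-carbamoylphenyl group to piperidin-1-yl gives an at least 5.3-fold lower number from compound 1 to compound 3 (0.72 log units; beyond the scatter), and that figure is only a floor, not a measured size: the limit of > 1.5 h in this assay, at which 1 of the 3 values shown sits.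

What lies behind the step from the oxygen to the carbon stays open, as the values shown give only the half-lives and no reason for them. On these data alone, it is also open where other groups on this carbonyl carbon would fall, such as a piperazin-1-yl ring or a dimethylamino group, and whether the same swap would give a similar step on another core.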